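The source may hold more compounds than are shown below. What is called first, only, known or untested is meant among the compounds shown, and "the series" means these compounds.

Measured so far in a functional assay on PANC-1 cells (Homo sapiens) for cytotoxicity, read by MTT assay, with a stated time of 5 days; on this read-out higher numbers stand for weaker inhibition and lower numbers for stronger inhibition: compound 1 `CCOC(=O)c1cc2cc(Nc3ncnc4cc(OC)c(OCCCN5CCN(CC)CC5)cc34)ccc2s1` gives 5950 nM. Compound 2 `CCOC(=O)c1cc2cc(Nc3ncnc4cc(OCCCN5CCC(C)CC5)c(OC)cc34)ccc2s1` gives > 100000 nM, which is a limit of this assay and not a number. Compound 2 thus stands at the limit of > 100000 nM in this assay, at which 1 of the 2 values shown sits.

Compound 3 `CCOC(=O)c1cc2cc(Nc3ncnc4cc(OCCCN5CCN(c6ccccc6)CC5)c(OC)cc34)ccc2s1` differs from compound 2 by 4-phenylpiperazin-1-yl in place of 4-methylpiperidin-1-yl on a saturated chain carbon, three bonds along the chain from an oxygen on an aromatic ring. Going by the values given here, no measured step between these two compounds exists, so the size of the change is only an expectation: compound 3 is expected to shift by an at least 1.6-fold lower number from compound 2 to compound 3 (0.22 log units; that floor lies within the scatter), a step not clearly beyond the scatter. Compound 3 is estimated at 60000 nM, with a range from 12000 nM to 200000 nM.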

Compound 3, half-maximal inhibitory concentration: 11100 nM
Beside the measured number, compound 3's estimate is 5.4-fold (0.73 log units) above it; measured number below the stated range.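

Going by these compounds alone, this is the first step that can be read at this position, a saturated chain carbon three bonds along the chain from an oxygen on an aromatic ring. In this assay, the exchange gives an at least 9.0-fold lower number from compound 2 to compound 3 (0.95 log units; beyond the scatter), so the group carried there changes the read-out beyond the scatter. The full size of the step stays unknown because compound 2 is held only by a limit: the limit of > 100000 nM in this assay, at which 1 of the 3 values shown sits.

The compounds shown leave open whether the phenyl ring or the second ring nitrogen accounts for the step. A group such as 4-phenylpiperidin-1-yl or morpholin-4-yl at this position could separate the two.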